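The compounds below may be only part of what the source reports. "The series", "measured", "known", "first", "only" and "open" are said of these compounds alone.

The measured compounds and their values:

Compound 1 `OB(O)c1ccc2ncnc(Nc3cccc(Cl)c3)c2c1`: in an assay on isolated protein for inhibition of vascular endothelial growth factor receptor 1 (Homo sapiens), read by ELISA, with a stated time of 20 min (a higher number here means a weaker inhibitor, a lower number a stronger inhibitor), compound 1 gives > 1000 nM, which is a limit of the assay and not a number.
Compound 2 `CC1(C)OB(c2ccc3ncnc(Nc4ccc(F)c(Cl)c4)c3c2)OC1(C)C`: in this assay compound 2 gives > 1000 nM, again only a limit.
Compound 3 `COc1cc2ncnc(Nc3cccc(Cl)c3)c2cc1B(O)O`: in this assay compound 3 gives > 1000 nM, once more a limit.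

Compound 4 `COc1cc2ncnc(Nc3ccc(F)c(Cl)c3)c2cc1B1OC(C)(C)C(C)(C)O1` has not yet been measured. From compound 1 to compound 3 the change is methoxy in place of hydrogen on an aromatic carbon, and the step that goes with it is a step that the two limits leave unreadable from compound 1 to compound 3. Going by these compounds, it cannot be read because of the limit of > 1000 nM in this assay, at which 3 of the 3 values shown sit, so whether the methoxy helps or hurts stays open.

Compound 4 stands to compound 2 as compound 3 stands to compound 1: the change is methoxy in place of hydrogen on an aromatic carbon. This is the same kind of change, not the same change, since around the place the surroundings differ: in compound 2 the entering methoxy is ortho to a group of 9 heavy atoms, whereas in compound 1 it is ortho to a group of 3 heavy atoms. How the core of compound 1 and the core of compound 2 differ is not broken down here.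

Since compound 2 sits at a limit and the only measured version of this change is unreadable, the step from compound 2 to compound 4 is expected to be a step that the limit leaves unreadable from compound 2 to compound 4, resting on nothing firmer than the shared limit. Compound 4 is therefore expected to give about 3000 nM in this assay, most likely again as a limit, with a range from 700 nM to 30000 nM.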

Compound 4, half-maximal inhibitory concentration: > 1000 nM
Compound 4: only a limit was reported; the forecaster's own chance of this, stated with the estimate: 85%; the middle value does not contradict the limit.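

Compound 2 and compound 4 both give only a limit and not a number, so the step between them cannot be read and no new size of change comes from this pair: the limit of > 1000 nM in this assay, at which 4 of the 4 values shown sit.

The compounds shown leave open how strongly any of them acts in this assay, and whether methoxy in place of hydrogen on an aromatic carbon helps or hurts.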